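Acyl variation on the fused piperazine series, spleen read-out

This account rests on a few compounds, and the source may have more. Where it says the series, first, only, none or still open, it means among the compounds named here.

Measured compounds:
compound 1 `COc1cc2nc(N3CCN(C(=O)c4ccc(Br)o4)[C@H]4CCCC[C@H]43)nc(N)c2cc1OC`: 8.5
compound 2 `COc1cc2nc(N3CCN(C(=O)c4ccc(C(C)=O)o4)[C@H]4CCCC[C@H]43)nc(N)c2cc1OC`: 8.13
compound 3 `COc1cc2nc(N3CCN(C(=O)c4ccc[nH]4)[C@H]4CCCC[C@H]43)nc(N)c2cc1OC`: 8.05

In a functional assay on spleen for antagonist activity at Alpha-1B adrenergic receptor (Rattus norvegicus) (on this read-out lower numbers stand for lower potency and higher numbers for higher potency (the scale is a negative logarithm)), compound 1 gives 8.5, the highest of the three numbers. Compound 2 gives 8.13 in this assay, and compound 3 gives 8.05. Both steps away from compound 1 lie beyond the scatter: a number 0.37 log units lower from compound 1 to compound 2 (beyond the scatter) and a number 0.45 log units lower from compound 1 to compound 3 (beyond the scatter). The pair compound 2 to compound 3 stays within the scatter, a number 0.08 log units lower from compound 2 to compound 3 (within the scatter).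

Compound 4 `COc1cc2nc(N3CCN(C(=O)c4ccccn4)[C@H]4CCCC[C@H]43)nc(N)c2cc1OC` has not yet been measured in this assay. Its change from compound 1 is pyridin-2-yl in place of 5-bromofuran-2-yl on a carbonyl carbon. Within the data shown here, two measured steps bear on this: changing the substituent on the furan, compound 1 to compound 2, and exchanging the whole five-membered ring, compound 1 to compound 3. Both were modest losses. Among the measured compounds shown here, a six-membered ring with one nitrogen and no bromine has no direct precedent here, so the size is uncertain, but a modest decrease from compound 1 is the expected direction.

Compound 4 is therefore expected to give 8.1 in this assay, within 7.6 to 8.6, meaning a step of a number 0.40 log units lower from compound 1 to compound 4 (beyond the scatter) that is expected to fall near the two measured losses.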

Compound 4, negative logarithm of the antagonist equilibrium constant: 8.64
Compound 4: middle estimate off by 0.54 log units, on the low side, outside the stated range (above it).
By their numbers in this assay, from the lowest: compounds 3 and 2 (each within the scatter of the next); then compounds 1 and 4 (each within the scatter of the next).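

In this assay, pyridin-2-yl on the carbonyl carbon gives a number level with that of 5-bromofuran-2-yl (a number 0.14 log units higher from compound 1 to compound 4 (within the scatter)), so neither the bromine nor a five-membered ring is needed for the top level seen at this position. The same group stands clear of the other two acyl groups (a number 0.59 log units higher from compound 3 to compound 4 (beyond the scatter)) and (a number 0.51 log units higher from compound 2 to compound 4 (beyond the scatter)), which places the four compounds in two levels that ring size alone does not sort: compound 1 carries a five-membered ring at the upper level alongside compound 4, while compounds 2 and 3 carry five-membered rings at the lower level. No measurement shown here accounts for why pyridin-2-yl and 5-bromofuran-2-yl stand level.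

The compounds shown leave open whether the ring nitrogen of pyridin-2-yl contributes to the number, a question that phenyl or pyridin-4-yl on the same carbonyl carbon would address. From the compounds shown here alone, it also remains open how much of the level of compound 1 depends on the bromo group, which unsubstituted furan-2-yl would separate from the contribution of the furan ring itself.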